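The compounds below may be only part of what the source reports. "The series", "measured", "known", "first", "only" and "open" are said of these compounds alone.

Working notes on the series. Compound 1 `COC(=O)/C=C/c1cccc(N(Cc2ccc(-c3ccc(F)c(F)c3)cc2)C(=O)C2CCCCC2)c1` gives 72 nM in an assay on isolated protein with Bile acid receptor (Homo sapiens) as the target (a higher number here means that more compound is needed for the effect, a lower number that less compound is needed), the lowest of the two numbers at hand; compound 2 `COC(=O)/C=C/c1cccc(N(Cc2ccc(-c3ccc(C)cc3)cc2)C(=O)NC(C)C)c1` gives 449 nM in this assay, a higher number than compound 1 by more than the scatter. Compound 3 `COC(=O)/C=C/c1cccc(N(Cc2ccc(/C=C/C(=O)NC(C)(C)C)cc2)C(=O)C2CCCCC2)c1` is not yet measured. Relative to compound 1 the structures differ as follows: 2-((tert-butyl)carbamoyl)ethenyl in place of 3,4-difluorophenyl on an aromatic carbon. Going by the values given here, nothing measured so far bears directly on this change; expected is a step of moderate size toward a higher number, a 2.5-fold higher number from compound 1 to compound 3 (0.40 log units; beyond the scatter), somewhat beyond the scatter. Compound 3 is accordingly estimated at 180 nM, with a range from 60 nM to 600 nM.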

Compound 3, half-maximal effective concentration: > 1000 nM
Compound 3: no number, only a limit (the forecaster's own chance of this, stated with the estimate: 5%); middle value at least 5.5-fold (0.74 log units) away from the limit.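

At this aromatic carbon, para to a large group, putting 2-((tert-butyl)carbamoyl)ethenyl in place of 3,4-difluorophenyl gives in this assay an at least 13-fold higher number from compound 1 to compound 3 (1.14 log units; beyond the scatter), the first large step read at this position. The result for compound 3 is a limit of the assay, not a number: the limit of > 1000 nM in this assay, at which 1 of the 3 values shown sits. The exchange removes an aromatic ring and brings in a chain with no ring, so this position is not indifferent to what it carries, even at a similar heavy-atom count.

The compounds shown do not separate the loss of the ring from the entry of the amide hydrogen. From the compounds shown here alone, how a carboxylic acid in place of the tert-butyl amide would read at this carbon remains open.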